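This account rests on a few compounds, and the source may have more. Where it says the series, first, only, none or still open, it means among the compounds named here.

Compound 3 `COc1cc2c(Nc3nc4ccc(C(=O)Nc5c(C)cccc5Cl)cc4s3)ncnc2cc1OCCCN1CCCC1` gives 19900 nM in a functional assay on U-937 cells (Homo sapiens) for cytotoxicity, read by WST assay, with a stated time of 72 h (on this read-out lower numbers stand for stronger inhibition and higher numbers for weaker inhibition), the highest of the three numbers measured; compound 1 `COc1cc2c(Nc3nc4ccc(C(=O)Nc5c(C)cccc5C)cc4s3)ncnc2cc1OCCCN1CCCC1` gives 18900 nM, and compound 2 `CCN(CC)CCCOc1cc2ncnc(Nc3nc4ccc(C(=O)Nc5c(C)cc(C)cc5C)cc4s3)c2cc1OC` gives 4300 nM. Compound 4 `COc1cc2c(Nc3nc4ccc(C(=O)Nc5c(C)cc(C)cc5C)cc4s3)ncnc2cc1OCCCN1CCCC1` differs from compound 3 by 2,4,6-trimethylphenyl in place of 2-chloro-6-methylphenyl on an amide-type nitrogen. Within the data shown here, only one measured step touches this position, a 1.1-fold higher number from compound 1 to compound 3 (0.02 log units; within the scatter), a swap of chloro for methyl that changed nothing beyond the scatter. Compound 2, which carries the same 2,4,6-trimethylphenyl as compound 4 on a different amine chain, stands well lower than compound 1 and compound 3, so a modest gain is expected from the step of a 2.5-fold lower number from compound 3 to compound 4 (0.40 log units; beyond the scatter). Compound 4 is therefore estimated at 8000 nM, with a range from 3000 nM to 20000 nM in this assay.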

Compound 4, half-maximal inhibitory concentration: 4600 nM
Compound 4: the middle estimate sits 1.7-fold (0.24 log units) above what was measured; low and high end bracket the measured number.
By their numbers in this assay, from the lowest: compounds 2 and 4 (each within the scatter of the next); then compounds 1 and 3 (each within the scatter of the next).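

In this assay, the 2,4,6-trimethylphenyl on the amide-type nitrogen gives a 4.3-fold lower number from compound 3 to compound 4 (0.64 log units; beyond the scatter), and methyl in place of hydrogen on an aromatic carbon alone gives a 4.1-fold lower number from compound 1 to compound 4 (0.61 log units; beyond the scatter), so this aryl group does move the number. Pyrrolidin-1-yl in place of diethylamino on the chain gives only a 1.1-fold higher number from compound 2 to compound 4 (0.03 log units; within the scatter), so compound 2 and compound 4 stand together. Nothing measured here accounts for the effect of this methyl. On these data alone, whether ethyl, methoxy or a dimethylamino group on that aromatic carbon would keep the lower number stays open.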